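The compounds below may be only part of what the source reports. "The series", "measured", "known", "first", "only" and "open" are said of these compounds alone.

Measured compounds:
compound 1, `O=C(CCCCC#Cc1ccc([N+](=O)[O-])cc1)c1ncc(-c2ccccn2)o1`: 31 nM
compound 2, `COC(=O)c1ccc(CCCCCCC(=O)c2ncc(-c3ccccn3)o2)cc1`: 1.5 nM

Both compounds share the same core, an oxazole ketone carrying a pyridine ring, and differ in the chain and the group on the distant benzene ring. In an assay for inhibition of Fatty-acid amide hydrolase 1 (Rattus norvegicus) (on this read-out higher numbers stand for weaker inhibition and lower numbers for stronger inhibition), compound 1 gives 31 nM, while compound 2 gives 1.5 nM, the lowest of the two numbers and a gap that lies beyond the usual scatter of repeats. Compound 2 is thus the stronger inhibitor of the pair in this assay.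

Compound 3, `Nc1ccc(CCCCCCC(=O)c2ncc(-c3ccccn3)o2)cc1`, has not yet been measured. It differs from compound 2 in one place: amino in place of methoxycarbonyl on an aromatic carbon. A smaller, donor-bearing group replaces an ester at the far end of the molecule. Within the data shown here, with no measured step of this kind available, the expectation is a moderate loss of potency, a step of a 4.0-fold higher number from compound 2 to compound 3 (0.60 log units; beyond the scatter) in this assay, possibly only at the edge of the scatter. Compound 3 is therefore estimated at 6 nM, with a likely range from 1.5 nM to 25 nM.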

Compound 3, inhibition constant: 3 nM
Beside the measured number, compound 3's estimate is 2.0-fold (0.30 log units) above it; low and high end bracket the measured number.
By their numbers in this assay, from the lowest: compounds 2 and 3 (each within the scatter of the next); then compound 1.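

In this assay, amino in place of methoxycarbonyl gives a 2.0-fold higher number from compound 2 to compound 3 (0.30 log units; within the scatter), so the two groups cannot be told apart at this aromatic carbon, para to a large group. The exchange is large on paper: a group of 4 heavy atoms with no hydrogen-bond donor gives way to a group of 1 heavy atom with 1 hydrogen-bond donor, and the number stays in the same range. The earlier pair, compound 1 and compound 2, differs in more than one place, so it could not isolate this position.

Going by these compounds, whether a carboxylic acid or a dimethylamino group on this same carbon would also stay in this range remains open. Nothing measured here tells why this exchange leaves the number within the scatter.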